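Diphenyl ether series: benzylamine side chain revisited

The source may hold more compounds than are shown below. What is called first, only, known or untested is meant among the compounds shown, and "the series" means these compounds.

Compound 3 `COc1cc(Oc2cccc(Nc3ccccc3)c2)cc(OC)c1CCO` gives 13900 nM in a functional assay on HT-29 cells (Homo sapiens) for inhibition, read by MTT assay, with a stated time of 72 h (on this read-out higher numbers stand for weaker inhibition and lower numbers for stronger inhibition), the highest of the two numbers recorded in the series. Compound 1 `COc1cc(Oc2cccc(Nc3ccccc3)c2)cc(OC)c1CNCc1ccccc1` gives 3340 nM; a 4.2-fold higher number from compound 1 to compound 3 (0.62 log units; beyond the scatter). Compound 2 `COc1cc(Oc2cccc(Nc3ccccc3)c2)cc(OC)c1CNC(C)C` is recorded only as a limit, > 20000 nM, as the limit of > 20000 nM in this assay, at which 1 of the 3 values shown sits, notes. The step of an at least 5.9-fold higher number from compound 1 to compound 2 (0.77 log units; beyond the scatter) therefore reads as a floor.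

Compound 4 `COc1cc(Oc2cccc(Nc3ccccc3)c2)cc(OC)c1CNCc1ccc(Br)cc1` carries (4-bromobenzyl)amino in place of hydroxymethyl on a saturated chain carbon bound to an aromatic carbon. The step from compound 3 to compound 4 reinstates the benzylamino chain of compound 1 and adds a bromine to its ring. The measured step that bears on it most directly is the reverse of a 4.2-fold higher number from compound 1 to compound 3 (0.62 log units; beyond the scatter), which puts compound 4 close to compound 1 before the bromine is considered; nothing measured in this set speaks to a substituent on that ring. Compound 2 suggests that an amine alone does not recover the number, as its limit shows.

For compound 4 the expectation is a 4.6-fold lower number from compound 3 to compound 4 (0.67 log units; beyond the scatter), an estimated value of 3000 nM in this assay, within 1000 nM to 10000 nM.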

Compound 4, half-maximal inhibitory concentration: 3060 nM
Compound 4: middle estimate off by 1.0-fold (0.01 log units), on the low side; the range from low to high includes it.
By their numbers in this assay, from the lowest: compounds 4 and 1 (each within the scatter of the next); then compound 3. At a limit, above all of these: compound 2.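

On the saturated chain carbon bound to an aromatic carbon, (4-bromobenzyl)amino in place of hydroxymethyl gives a 4.5-fold lower number from compound 3 to compound 4 (0.66 log units; beyond the scatter), so the benzylamino chain keeps its advantage over hydroxymethyl with a bromo on its ring. Going by these compounds alone, this is the first reading of a substituent on that ring, and bromo in place of hydrogen on an aromatic carbon gives a 1.1-fold lower number from compound 1 to compound 4 (0.04 log units; within the scatter) in this assay, so the two benzylamines cannot be separated on this read-out. With 4-bromobenzyl in place of isopropyl on the amine nitrogen, the step of an at least 6.5-fold lower number from compound 2 to compound 4 (0.81 log units; beyond the scatter) is only a floor, as compound 2 is recorded as a limit: the limit of > 20000 nM in this assay, at which 1 of the 4 values shown sits.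

Going by these compounds, whether a methoxy, a nitrile or a carboxylic acid on that ring would move the number remains open. So does the effect of a cyclohexylmethyl group or a longer chain between the amine nitrogen and the ring.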